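Methyl for methylsulfonyl on the longer-chain series

The compounds below may be only part of what the source reports. "The series", "measured", "known", "first", "only" and "open" are said of these compounds alone.

Measured so far in a functional assay on PC-3 cells (Homo sapiens) for cytotoxicity (on this read-out lower numbers stand for stronger inhibition and higher numbers for weaker inhibition), as follows
- compound 1 `O=C(CCCCCCC(=O)Nc1nc2ccccc2s1)NO` gives 5.44 ug/mL as a number
- compound 2 `CS(=O)(=O)c1ccc2nc(NC(=O)CCCCCCC(=O)NO)sc2c1` gives 5.69 ug/mL as a number
- compound 3 `CS(=O)(=O)c1ccc2nc(NC(=O)CCCCC(=O)NO)sc2c1` gives > 30 ug/mL as a limit

Compound 1 at 5.44 ug/mL and compound 2 at 5.69 ug/mL lie within the scatter of each other. Compound 3 stands at > 30 ug/mL as a limit of the assay and not as a number.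

Compound 4 `Cc1ccc2nc(NC(=O)CCCCCCC(=O)NO)sc2c1` keeps the chain of compound 2 and differs from it in one place (methyl in place of methylsulfonyl on an aromatic carbon) with methyl in place of methylsulfonyl on an aromatic carbon. The measured step that bears on this change is methylsulfonyl in place of hydrogen on an aromatic carbon, which came out as a 1.0-fold higher number from compound 1 to compound 2 (0.02 log units; within the scatter) in this comparison. The other measured step, an at least 5.2-fold higher number from compound 2 to compound 3 (0.72 log units; beyond the scatter) for hydroxycarbamoyl in place of 2-(hydroxycarbamoyl)ethyl, concerns the chain, which compound 4 leaves untouched, so it does not carry over. Going by the values given here, no methyl compound has been measured, and the expectation rests on a single step.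

The size expected in this assay is a 1.0-fold lower number from compound 2 to compound 4 (0.01 log units; within the scatter) and thus no estimated change beyond the scatter in either direction. Compound 4 is estimated at 5.5 ug/mL with an expected range from 2.5 ug/mL to 12 ug/mL in this assay.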

Compound 4, half-maximal inhibitory concentration: 0.53 ug/mL
Compound 4: the middle estimate sits 10-fold (1.02 log units) above what was measured; measured number below the stated range.
By their numbers in this assay, from the lowest: compound 4; then compounds 1 and 2 (each within the scatter of the next). At a limit, above all of these: compound 3.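

In this assay, the three groups at this aromatic carbon do not behave alike: the methyl compound separates from both others, with an 11-fold lower number from compound 2 to compound 4 (1.03 log units; beyond the scatter) and a 10-fold lower number from compound 1 to compound 4 (1.01 log units; beyond the scatter), while hydrogen and methylsulfonyl gave only a 1.0-fold higher number from compound 1 to compound 2 (0.02 log units; within the scatter). The earlier pair alone made this position look insensitive to what it carries, and compound 4 shows that this was true only of those two groups. The read-out also does not follow the size of the group, since methyl, with its single heavy atom, stands apart while hydrogen and the four heavy atoms of methylsulfonyl remain within the scatter of each other, and no available evidence explains this difference.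

From the compounds shown here alone, it remains open whether the gain belongs to methyl alone or extends to other groups at this carbon, such as ethyl, methoxy, chlorine or an amine. Going by these compounds, it is equally open whether methyl would also lower the number on the shorter chain of compound 3, whose entry in this assay is a limit of the assay, > 30 ug/mL, and not a number.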